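Ester Chain Extension and Intestinal Microsomal Half-Life

The source may hold more compounds than are shown below. What is called first, only, known or untested is meant among the compounds shown, and "the series" means these compounds.

Measured compounds:
Compound 1, `CCOc1cc(NC(=O)C2(NC(=O)c3ccc4c(C5CCCC5)c(-c5ncc(Cl)cn5)n(C)c4c3)CCC2)ccc1/C=C/C(=O)OCOP(=O)(O)O`, gives 0.467 h in an ADME assay (intestine, Homo sapiens) for pharmacokinetics, using microsomes; on this read-out lower numbers stand for a shorter-lived compound and higher numbers for a longer-lived compound.
Compound 2, `CCOC(=O)/C=C/c1ccc(NC(=O)C2(NC(=O)c3ccc4c(C5CCCC5)c(-c5ncc(Cl)cn5)n(C)c4c3)CCC2)cc1OCC`, gives > 5 h in this assay, which is a limit of the assay and not a number.

The limit for compound 2 is recorded as the limit of > 5 h in this assay, at which 1 of the 2 values shown sits. Compound 2 therefore stands at the long-lived end of the two values shown, with only a range known for it, not a point.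

Compound 3, `CCCOC(=O)/C=C/c1ccc(NC(=O)C2(NC(=O)c3ccc4c(C5CCCC5)c(-c5ncc(Cl)cn5)n(C)c4c3)CCC2)cc1OCC`, differs from compound 2 by methyl in place of hydrogen on a saturated chain carbon, two bonds along the chain from an oxygen next to a carbonyl group. Among the compounds with values here, the only measured step, an at least 10-fold higher number from compound 1 to compound 2 (1.02 log units; beyond the scatter), replaces a phosphorus-bearing group with a carbon at the ester oxygen; it touches the same ester side chain but is a change of a very different kind from adding one methyl to an alkyl ester, so it bears on the present step only loosely. Within the data shown here, with no measured step of comparable nature, the expectation for the step from compound 2 to compound 3 is none beyond the scatter, a number no higher from compound 2 to compound 3 (the limit leaves the size open), and compound 3 is likely to sit at or near the same limit. Compound 3 is thus estimated at 5 h, with a range of 1.5 h to 12 h.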

Compound 3, half-life: > 5 h
Compound 3 was reported as a limit; the forecaster's own chance of this, stated with the estimate: 60%; the middle value sits exactly at the limit.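

In this assay compound 3 gives > 5 h, which is a limit of the assay and not a number. Exchanging the phosphorus-bearing group at the ester oxygen for the propyl chain gives an at least 10-fold higher number from compound 1 to compound 3 (1.02 log units; beyond the scatter), so the large step seen with the ethyl ester recurs with a second simple alkyl ester, and the long-lived reading at this position is not confined to ethyl. The effect of ethyl to propyl itself cannot be read, and compound 2 and compound 3 cannot be ordered, because both sit at the same limit: the limit of > 5 h in this assay, at which 2 of the 3 values shown sit.

Going by these compounds, how far either ester lies past the limit remains open, so any effect of the added methyl may be hidden there, and only a read-out extending beyond the limit could separate the two. Also open, on these data alone, is whether a longer chain, a branched chain such as isopropyl, or an ester chain ending in an amine or a carboxylic acid would stay at the limit or fall towards compound 1.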